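Swapping the glycinamide tail for a hydroxyethyl chain

The source may hold more compounds than are shown below. What is called first, only, known or untested is meant among the compounds shown, and "the series" means these compounds.

Measured so far in an ADME assay on HEp-2 cells (Homo sapiens) for cytotoxicity, read by CCK-8 assay, with a stated time of 5 days; a higher number here means that more compound is tolerated, a lower number that less compound is tolerated:
- compound 1, `Cc1ccc2nc(N3CCCc4ccc(F)cc4C3)cc(NCCN(C)C)c2c1`, gives 89000 nM
- compound 2, `Cc1ccc2nc(N3CCCc4ccc(F)cc4C3)cc(NCC(C)(C)N)c2c1`, gives 23000 nM
- compound 3, `Cc1ccc2nc(N3CCCc4ccc(F)cc4C3)cc(NC(=O)CN)c2c1`, gives > 100000 nM, which is a limit of the assay rather than a number

Compound 3 therefore sits at the tolerated end of the three. The step of an at least 1.1-fold higher number from compound 1 to compound 3 (0.05 log units; that floor lies within the scatter) lies within the scatter, while an at least 4.3-fold higher number from compound 2 to compound 3 (0.63 log units; beyond the scatter) and a 3.9-fold lower number from compound 1 to compound 2 (0.59 log units; beyond the scatter) are beyond it. The value of compound 3 is a limit, as noted in the limit of > 100000 nM in this assay, at which 1 of the 3 values shown sits.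

Compound 4, `Cc1ccc2nc(N3CCCc4ccc(F)cc4C3)cc(NCCO)c2c1`, differs from compound 3 by 2-hydroxyethyl in place of (aminomethyl)carbonyl on a nitrogen on an aromatic ring. For the measured compounds named here, no measured step changes this nitrogen substituent in the same way, so the expectation rests only on compound 3 standing at the limit and on the spread among compounds 1, 2 and 3 being modest. The expected step of an at least 1.1-fold lower number from compound 3 to compound 4 (0.04 log units; that floor lies within the scatter) is estimated to stay near the scatter. Compound 4 is therefore expected to give about 90000 nM, within a range of 35000 nM to 200000 nM, with a fair chance that only a limit is again reported.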

Compound 4, half-maximal cytotoxic concentration: > 100000 nM
Compound 4: no number, only a limit; the forecaster's own chance of this, stated with the estimate: 45%; middle value at least 1.1-fold (0.04 log units) from the limit.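

In this assay compound 4 gives > 100000 nM and that is a limit of the assay, not a number, so the step from compound 3 cannot be read: the limit of > 100000 nM in this assay, at which 2 of the 4 values shown sit. What is new is that a 2-hydroxyethyl tail, with no amine in it, also reaches this limit, so among these compounds the nitrogen substituent needs no amine to be tolerated this well. Replacing the tail of compound 2 gives an at least 4.3-fold higher number from compound 2 to compound 4 (0.63 log units; beyond the scatter) and stands beyond the scatter, while replacing that of compound 1 gives an at least 1.1-fold higher number from compound 1 to compound 4 (0.05 log units; that floor lies within the scatter) and has a floor within it.

As far as these compounds go, how far compound 3 and compound 4 lie past the limit stays unknown, so they cannot be ordered. From the compounds shown here alone, whether a longer chain such as 3-hydroxypropyl, or a carboxylic acid on this nitrogen, would also reach the limit remains open.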